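Methoxy for Chloro on a Hydrazone Whose Activity Is a Limit

The compounds below may be only part of what the source reports. "The series", "measured", "known", "first", "only" and "open" are said of these compounds alone.

Measured compounds:
compound 1 `Cc1nc(N(C)C(=O)NC(=O)c2c(F)cccc2F)sc1C(=O)N/N=C/c1ccc(Cl)cc1` gives > 100 ug/mL in a functional assay on HepG2 cells (Homo sapiens) for inhibition, read by MTT assay, with a stated time of 72 h (a lower number here means a stronger inhibitor, a higher number a weaker inhibitor), a limit of the assay rather than a number.
compound 2 `CN(C(=O)NC(=O)c1ccc(Cl)c(Cl)c1)c1nc(C(F)(F)F)c(C(=O)N/N=C/c2ccc([N+](=O)[O-])cc2)s1` gives 6.85 ug/mL in this assay.

Compound 1 therefore stands at the upper edge of the measured range: its result is only a limit, the point named in the limit of > 100 ug/mL in this assay, at which 1 of the 2 values shown sits. Going by the values given here, compound 2 differs from compound 1 in several places at once, and no step between the two is computed; their two values show only that compound 2 gave a number while compound 1 did not.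

Compound 3 `COc1ccc(/C=N/NC(=O)c2sc(N(C)C(=O)NC(=O)c3c(F)cccc3F)nc2C)cc1` is the closest relative of compound 1. It differs from it by methoxy in place of chloro on an aromatic carbon. Among the compounds with values here, nothing among the measured compounds tells what this change does in this assay. With compound 1 known only as a limit, the estimate for compound 3 is placed near that limit, and no step beyond the scatter is expected: from compound 1 to compound 3 the expected change is a number no higher from compound 1 to compound 3 (the limit leaves the size open). Compound 3 is thus expected at 100 ug/mL, in a range from 35 ug/mL to 250 ug/mL, with a substantial chance that this assay again reports only a limit.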

Compound 3, half-maximal inhibitory concentration: 22.7 ug/mL
Compound 3: middle estimate off by 4.4-fold (0.64 log units), on the high side; measured number below the stated range.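

Going by these compounds alone, the 4-chlorophenyl to 4-methoxyphenyl change gives the first readable step: methoxy in place of chloro on an aromatic carbon, para to a large group, brings an at least 4.4-fold lower number from compound 1 to compound 3 (0.64 log units; beyond the scatter) in this assay. This shows that the position is not silent, since one change there, with the rest of the structure of compound 1 kept, is enough to turn a result without a number into compound 3 at 22.7 ug/mL. Compound 1 is known only as a limit, so the step has a floor but no known full size: the limit of > 100 ug/mL in this assay, at which 1 of the 3 values shown sits.

The compounds shown do not tell whether the step comes from the loss of chloro or from the arrival of methoxy, and a plain hydrogen, a hydroxyl, an amine or a longer ether chain such as ethoxy at the same place would be needed to separate the two. They also leave open whether methoxy in place of chloro would act in the same way on a compound with a different core, such as compound 2, whose aromatic ring carries a nitro group at this place instead.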